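Swapping an Alkyne for an Alkene on a Quinoline-Free Core

The source may report more compounds than this note shows. Statements on the series, on what has been measured and on what is new or still open speak of the compounds shown alone.

Three compounds share one core, shown by the structure of compound 1 `CC#CCCOc1cccc2ccc(N)nc12`, and differ in the chain carried on the oxygen and in the amine. They were tested in an assay on cells with melanin-concentrating hormone receptor 1 (Homo sapiens) as the target, read by radioligand binding; on this read-out higher numbers stand for weaker inhibition and lower numbers for stronger inhibition. Compound 1 gives > 2000 nM, which is a limit of the assay rather than a number. Compound 2 `CCC(CC)C(C)Oc1cccc2ccc(N)nc12` carries a branched saturated chain and in this assay gives 191 nM. Compound 3 `CC(CC(C)(C)C)Oc1cccc2ccc(N(C)C)nc12`, with a dimethylated amine, gives > 2000 nM, again a limit rather than a number. So compound 1 sits at the limit of > 2000 nM in this assay, at which 2 of the 3 values shown sit, together with compound 3, while compound 2 alone returns a number.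

Compound 4 `CC(C)=CCOc1cccc2ccc(N)nc12` has not been measured. The change from compound 1 is 2-methylprop-1-en-1-yl in place of but-2-yn-1-yl on a saturated chain carbon bound to an oxygen on an aromatic ring. The chain keeps the same number of carbons and loses its triple bond for a double bond with branching.

For the measured compounds named here, because compound 1 sits at the limit of > 2000 nM in this assay, at which 2 of the 3 values shown sit, no measured step from a comparable pair is available, and the expected step of a number no higher from compound 1 to compound 4 (the limit leaves the size open) in this assay is essentially nil, with wide uncertainty. Compound 4 is therefore estimated at 2000 nM, within a range from 400 nM to 10000 nM, and a limit is expected about as often as a number.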

Compound 4, half-maximal inhibitory concentration: > 2000 nM
Compound 4: only a limit was reported; the forecaster's own chance of this, stated with the estimate: 55%; the middle value lies on the limit itself.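

In this assay compound 4 gives > 2000 nM, a limit of the assay and not a number. The step between compound 1 and compound 4 cannot be read, because both rest on the same limit: the limit of > 2000 nM in this assay, at which 3 of the 4 values shown sit. The compounds shown leave open whether 2-methylprop-1-en-1-yl in place of but-2-yn-1-yl changes the inhibition at all, and by how much.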